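The source may hold more compounds than are shown below. What is called first, only, known or untested is meant among the compounds shown, and "the series" means these compounds.

Measured compounds:
Compound 1, `CNC(=O)C(CC1CCCCC1)Nc1nc2cc(C)ccc2o1`: 72 nM
Compound 2, `Cc1ccc2oc(NC(CC3CCCCC3)C3=CN(C)NO3)nc2c1`: 26 nM

Of the compounds shown here, two have been measured in a functional assay for inhibition, with Homo sapiens as the target; on this read-out higher numbers stand for weaker inhibition and lower numbers for stronger inhibition. Going by the values given here, compound 1 gives 72 nM and compound 2 gives 26 nM, so compound 2 holds the lower of the two numbers, and the single measured step is a 2.8-fold lower number from compound 1 to compound 2 (0.44 log units; beyond the scatter). Compound 3, `Cc1ccc2oc(NC(CC3CCCCC3)c3ccccn3)nc2c1`, has not yet been measured. It differs from compound 2 at the same position that the measured step altered: a group of 6 heavy atoms (5 carbon, 1 nitrogen; one six-membered aromatic ring with 1 hetero atom) in place of a group of 6 heavy atoms (3 carbon, 2 nitrogen, 1 oxygen; one five-membered non-aromatic ring with 3 hetero atoms), on a saturated chain carbon bound to a nitrogen on an aromatic ring and a saturated chain carbon. Among the compounds with values here, that measured step put the five-membered ring of compound 2 in place of a group with no ring; no measured step swaps that ring for a pyridin-2-yl, so the one step available bears only indirectly on the change to compound 3. Within the data shown here, nothing among the measured compounds marks the aromatic ring as better or worse than the ring it replaces. For compound 3 the step expected from this is a 1.5-fold higher number from compound 2 to compound 3 (0.19 log units; within the scatter), that is, no shift beyond the scatter, with a wide range to allow either direction. Compound 3 is therefore estimated at 40 nM in this assay, between 10 nM and 160 nM.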

Compound 3, half-maximal inhibitory concentration: 4 nM
Beside the measured number, compound 3's estimate is 10-fold (1.00 log units) above it, outside the stated range (below it).
By their numbers in this assay, from the lowest: compound 3; then compound 2; then compound 1.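

In this assay, the place on a saturated chain carbon bound to a nitrogen on an aromatic ring and a saturated chain carbon turns out to respond strongly to the identity of the ring it carries: pyridin-2-yl gives a 6.5-fold lower number from compound 2 to compound 3 (0.81 log units; beyond the scatter), even though the group leaving and the group entering have the same count of heavy atoms, so that count alone does not set the number here. Set against the open-chain methylcarbamoyl, pyridin-2-yl gives an 18-fold lower number from compound 1 to compound 3 (1.26 log units; beyond the scatter), the largest step yet seen at this place, and compound 3 now holds the lowest number of the three. Nothing measured on these groups accounts for either step.

The compounds shown do not separate the effect of the aromatic ring itself from that of its ring nitrogen and where that nitrogen sits, a question that phenyl, pyridin-3-yl or pyridin-4-yl at this place would address. Going by these compounds, it also remains open whether an amine or a carboxylic acid placed on this same carbon would keep a number close to that of compound 3.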